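The source may report more compounds than this note shows. Statements on the series, on what has been measured and on what is new or still open speak of the compounds shown alone.

Compound 1 `Cc1ccc([C@@H]2C[C@H](O)Cc3ccccc3N2)s1` stands at the highest of the two numbers measured here in an ADME assay on THP-1 cells (Homo sapiens) for cytotoxicity (on this read-out higher numbers stand for lower toxicity in this test and lower numbers for higher toxicity in this test), where compound 1 gives 608000 nM. Compound 3 `Cc1ccc([C@@H]2C[C@H](O)Cc3cc(OC(F)(F)F)ccc3N2)s1`, which carries a trifluoromethoxy group on an aromatic carbon, gives 98000 nM in this assay, a step of a 6.2-fold lower number from compound 1 to compound 3 (0.79 log units; beyond the scatter). Compound 2 `Cc1ccc([C@@H]2C[C@H](O)Cc3cc(Cl)ccc3N2)s1` reaches only a limit in this assay, namely > 2040000 nM (the limit of > 2040000 nM in this assay, at which 1 of the 3 values shown sits). The remaining steps are an at least 3.3-fold higher number from compound 1 to compound 2 (0.52 log units; beyond the scatter) and an at least 20-fold lower number from compound 2 to compound 3 (1.31 log units; beyond the scatter).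

Compound 4 `Cc1ccc([C@@H]2C[C@H](O)Cc3ccccc3N2)o1` differs from compound 1 in a different way: 5-methylfuran-2-yl in place of 5-methylthiophen-2-yl on a saturated ring carbon. All three measured steps exchange a substituent on the aromatic ring of the shared core, not the group on the saturated ring carbon, so none of them bears directly on this exchange. The expectation for compound 4 in this assay is therefore a step of a 1.0-fold lower number from compound 1 to compound 4 (0.01 log units; within the scatter), nothing beyond the scatter. Compound 4 is estimated at 600000 nM, with a range from 200000 nM to 1800000 nM.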

Compound 4, half-maximal cytotoxic concentration: 262000 nM
Estimate against measurement, compound 4: 2.3-fold (0.36 log units) above; low and high end bracket the measured number.
By their numbers in this assay, from the lowest: compound 3; then compound 4; then compound 1. At a limit, above all of these: compound 2.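

Among the compounds shown here, the group on the saturated ring carbon next to the ring nitrogen also matters in this assay: the earlier steps all changed a substituent on the aromatic ring of the shared core, whereas oxygen in place of sulfur within the five-membered aromatic ring gives a 2.3-fold lower number from compound 1 to compound 4 (0.37 log units; beyond the scatter). So 5-methylfuran-2-yl in place of 5-methylthiophen-2-yl, a change of one ring atom, moves the read-out toward higher toxicity in this test. Nothing measured here accounts for this step.

From the compounds shown here alone, it remains open whether the same exchange would have a similar effect with chloro or trifluoromethoxy on the aromatic ring, since compound 4 carries hydrogen there. Going by these compounds, how an unsubstituted phenyl ring, a propyl chain or a group bearing an amine would read at this saturated ring carbon also remains open.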